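The source may hold more compounds than are shown below. What is called first, only, known or untested is meant among the compounds shown, and "the series" means these compounds.

In a functional assay on HL-60 cells (Homo sapiens) for cytotoxicity, read by MTT assay, with a stated time of 4 days (a lower number here means a stronger inhibitor, a higher number a weaker inhibitor), compound 1, `C=C1C(=O)[C@]23C[C@@]1(O)CC[C@H]2c1ccc(O)c(C)c1[C@@H]3Cn1cc(-c2ccccn2)nn1`, gives 1970 nM. Compound 2, `C=C1C[C@]23C[C@@]1(O)CC[C@@H]2c1cccc(C)c1[C@@H]3Cn1cc(-c2ccc(OC)cc2)nn1`, is built on a related core and carries a 4-methoxyphenyl group. For compound 2 the result in this assay is only a limit, > 20000 nM, and not a number. For compound 3, `COc1ccc(-c2cn(C[C@H]3c4c(ccc(OS(=O)(=O)c5ccc(C)cc5)c4C)[C@@H]4CC[C@@]5(C)C[C@]43CC5=O)nn2)cc1`, this assay likewise reports only a limit, > 20000 nM. Compound 2 therefore stands at the limit of > 20000 nM in this assay, at which 2 of the 3 values shown sit; among the three measured compounds only compound 1 has a number. Compound 4, `C=C1C[C@]23C[C@@]1(O)CC[C@@H]2c1cccc(C)c1[C@@H]3Cn1cc(-c2ccccc2)nn1`, is not yet measured. It differs from compound 2 by hydrogen in place of methoxy on an aromatic carbon. For the measured compounds named here, no measured pair shows what this change does in this assay, so no observed step can guide it. The step is expected to be none beyond the scatter, a step that the limit leaves unreadable from compound 2 to compound 4, because compound 2 itself reaches only the limit > 20000 nM in this assay. Compound 4 is expected at about 25000 nM, within a range from 8000 nM to 80000 nM, and may well be reported only as a limit.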

Compound 4, half-maximal inhibitory concentration: > 20000 nM
Compound 4: a limit, no number; the forecaster's own chance of this, stated with the estimate: 70%; the middle value is on the limit's open side.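

Compound 2 and compound 4 each give only a limit and not a number, so no step between them can be read: the limit of > 20000 nM in this assay, at which 3 of the 4 values shown sit.

The compounds shown leave open what the change from 4-methoxyphenyl to phenyl does in this assay.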